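Acetyl exchange on the shared core under cytotoxicity testing

The source may hold more compounds than are shown below. What is called first, only, known or untested is meant among the compounds shown, and "the series" means these compounds.

The values measured in an ADME assay on MT4 cells (Homo sapiens) for cytotoxicity, read by MTT assay, with a stated time of 96 h (on this read-out lower numbers stand for higher toxicity in this test and higher numbers for lower toxicity in this test), are these
compound 1 `CC(=O)c1ccc2[nH]c(-c3ccccc3)nc2c1` gives "not determined" (no result reported)
compound 2 `CC(=O)c1ccc2c(c1)nc(-c1ccccc1)n2C1CCCCC1` gives 37000 nM
compound 3 `CC(=O)c1ccc2c(c1)nc(-c1ccc(Cl)cc1)n2C1CCCCC1` gives 58000 nM

For the measured compounds named here, compound 2 lies within the scatter of compound 3, the only other number, so it holds no separate rank. Compound 1 offers no number for comparison. The exchange in question (a group of 7 heavy atoms (3 carbon, 3 nitrogen, 1 sulfur; no ring) in place of a group of 3 heavy atoms (2 carbon, 1 oxygen; no ring), on an aromatic carbon) leads to compound 4 (`C/C(=N\NC(N)=S)c1ccc2c(c1)nc(-c1ccccc1)n2C1CCCCC1`). Going by the values given here, the single measured step (a 1.6-fold higher number from compound 2 to compound 3 (0.20 log units; within the scatter)) concerns chloro in place of hydrogen, not the acetyl group, so it offers little guidance here. A moderate move toward a lower number is expected, with wide uncertainty (a 2.5-fold lower number from compound 2 to compound 4 (0.39 log units; beyond the scatter)). The estimated value for compound 4 is 15000 nM (expected range 4000 nM to 50000 nM).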

Compound 4, half-maximal cytotoxic concentration: 20000 nM
Compound 4: middle estimate off by 1.3-fold (0.12 log units), on the low side; low and high end bracket the measured number.
By their numbers in this assay, from the lowest: compounds 4, 2 and 3 (each within the scatter of the next, the first and the last beyond it).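

Unlike the chloro step, this exchange touches the acetyl position itself. In this assay, replacing acetyl on this aromatic carbon with a group of 7 heavy atoms, carrying 2 hydrogen-bond donors, gives a 1.9-fold lower number from compound 2 to compound 4 (0.27 log units; within the scatter), so even this large an exchange leaves the number inside the scatter. Nothing available bears on why this is so. On these data alone, whether an amine or a carboxylic acid at this position would also stay within the scatter remains open, as does whether the exchange would give the same result alongside the chloro group.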